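The source may report more compounds than this note shows. Statements on the series, on what has been measured and on what is new or still open speak of the compounds shown alone.

This account follows a small set of compounds sharing one core, examined for solubility in a physicochemical assay for solubility; a higher number here means a more soluble compound, a lower number a less soluble compound. Compound 1 `CNC(=O)c1cc(C(=O)NCCCC2CNCCO2)cn(Cc2ccccc2)c1=O` sits at a limit of this assay, returning >= 194 ug/mL, so only a bound is known for it. Compound 2 `CNC(=O)c1cc(C(=O)NC2CCC2)cn(Cc2ccncc2)c1=O` likewise returns a limit, >= 118 ug/mL in this assay. Compound 3 `CNC(=O)c1cc(C(=O)NCCOC)cn(Cc2ccccc2)c1=O` has not yet been measured; it differs from compound 1 by methoxy in place of (morpholin-2-yl)methyl on a saturated chain carbon, two bonds along the chain from an amide-type nitrogen. Among the compounds with values here, no measured step between compounds is available to guide the change, and the step of an at least 1.6-fold lower number from compound 1 to compound 3 (0.20 log units; that floor lies within the scatter) is expected to run downward by a modest amount. Compound 3 is therefore expected to give 120 ug/mL, with a range from 40 ug/mL to 300 ug/mL.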

Compound 3, solubility: >= 164 ug/mL
Compound 3 ended at the assay's limit; the forecaster's own chance of this, stated with the estimate: 40%; middle value at least 1.3-fold (0.13 log units) away from the limit.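

Within the data shown here, compound 1 and compound 3 both return limits in this assay, and no step between them can be read. On these data alone, the true value of each compound, and the size of any difference between them, remain open.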